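Swapping trifluoromethyl for chloro on the benzylamine ring

The source may report more compounds than this note shows. Statements on the series, on what has been measured and on what is new or still open speak of the compounds shown alone.

Compound 1 `COc1cccc(CNCCCNS(=O)(=O)c2cc(C(F)(F)F)cc(C(F)(F)F)c2)c1` gives 2400 nM
Compound 2 `O=S(=O)(NCCCNCc1ccc(C(F)(F)F)cc1)c1cc(C(F)(F)F)cc(C(F)(F)F)c1` gives 1400 nM
Compound 3 `O=S(=O)(NCCCNCc1ccc(Cl)c(C(F)(F)F)c1)c1cc(C(F)(F)F)cc(C(F)(F)F)c1` gives 3500 nM

All three were measured in a functional assay on MCF7 cells (Homo sapiens) for inhibition, read by MTT assay, with a stated time of 72 h; on this read-out higher numbers stand for weaker inhibition of growth and lower numbers for stronger inhibition of growth. Compound 3 stands highest of the three numbers: the step of a 1.5-fold higher number from compound 1 to compound 3 (0.16 log units; within the scatter) is within the scatter, while the step of a 2.5-fold higher number from compound 2 to compound 3 (0.40 log units; beyond the scatter) is the only one beyond the scatter. The step of a 1.7-fold lower number from compound 1 to compound 2 (0.23 log units; within the scatter) is within the scatter.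

Compound 4 `O=S(=O)(NCCCNCc1ccc(Cl)c(Cl)c1)c1cc(C(F)(F)F)cc(C(F)(F)F)c1` differs from compound 3 by chloro in place of trifluoromethyl on an aromatic carbon. No measured step swaps these two groups on that ring, so nothing shown bears directly on the change; the aryl variations seen so far have moved the numbers by modest amounts at most. Compound 4 is therefore expected to sit close to compound 3, with an estimated step of a 1.2-fold lower number from compound 3 to compound 4 (0.07 log units; within the scatter). The estimate for compound 4 is 3000 nM, in the range 1200 nM to 7500 nM.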

Compound 4, concentration for 50% growth inhibition: 2400 nM
Compound 4: middle estimate off by 1.3-fold (0.10 log units), on the high side; measured number inside the range.
By their numbers in this assay, from the lowest: compounds 2, 1, 4 and 3 (each within the scatter of the next, the first and the last beyond it).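

In this assay, going by these compounds alone, chloro in place of trifluoromethyl on an aromatic carbon ortho to a chloro group gives a 1.5-fold lower number from compound 3 to compound 4 (0.16 log units; within the scatter), the first direct reading of this swap. The 3,4-dichlorophenyl ring stays within the scatter of both other aryl groups, with a 1.7-fold higher number from compound 2 to compound 4 (0.23 log units; within the scatter) and no change at the digits printed from compound 1 to compound 4 (within the scatter), whereas a 2.5-fold higher number from compound 2 to compound 3 (0.40 log units; beyond the scatter). No separate measurement bears on this result.

As far as these compounds go, whether a nitrile at this place would stay within the scatter remains open. So does whether the swap would read the same with a longer chain in the core.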